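The source may report more compounds than this note shows. Statements on the series, on what has been measured and on what is new or still open speak of the compounds shown alone.

Measured so far in an ADME assay on MT4 cells (Homo sapiens) for cytotoxicity, read by MTT assay; a lower number here means that less compound is tolerated, a higher number that more compound is tolerated:
Compound 1 `O=c1cc(Cc2c(F)cccc2F)nc(SCc2ccccc2)[nH]1`: > 73000 nM
Compound 2 `O=c1cc(Cc2c(F)cccc2F)nc(SCc2c(F)cccc2F)[nH]1`: > 66000 nM
Compound 3 `CC(=O)CSc1nc(Cc2c(F)cccc2F)cc(=O)[nH]1`: > 81000 nM

Each of these entries is a limit and not a number. Compound 3 therefore stands only at the limit of > 81000 nM in this assay, at which 1 of the 3 values shown sits, and no cytotoxic concentration can be read for it.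

Compound 4 `O=C(CSc1nc(Cc2c(F)cccc2F)cc(=O)[nH]1)c1ccc(Cl)cc1` differs from compound 3 by one change, 4-chlorophenyl in place of methyl on a carbonyl carbon. Among the measured compounds shown here, two measured steps bear on it, since both exchange acetyl for a group with a six-membered aromatic ring or the reverse: a step that the two limits leave unreadable from compound 1 to compound 3 and a step that the two limits leave unreadable from compound 2 to compound 3. Neither has a readable size. Where compound 3 has the acetyl, compound 1 has a phenyl and also gives only a limit, > 73000 nM. Compound 2, with 2,6-difluorophenyl there, likewise gives only a limit, > 66000 nM.

So no step beyond the scatter is expected, in either direction, and an at least 1.3-fold lower number from compound 3 to compound 4 (0.13 log units; that floor lies within the scatter) is only an estimate. The expected value for compound 4 is 60000 nM, with an estimated range of 30000 nM to 85000 nM, most likely reported again as a limit.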

Compound 4, half-maximal cytotoxic concentration: > 61000 nM
Compound 4 was reported as a limit; the forecaster's own chance of this, stated with the estimate: 75%; middle value at least 1.0-fold (0.00 log units) away from the limit.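

In this assay, among the compounds shown here, compound 4 gives > 61000 nM, which is a limit and not a number, and compounds 1, 2 and 3 also give only limits, so no step to compound 4 can be read. The compounds shown leave open the concentration at which any of them harms these cells, and whether 4-chlorophenyl in place of methyl changes it.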